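Replacing 3-methyloxetan-3-yl in compound 1

The compounds below may be only part of what the source reports. "The series", "measured", "known", "first", "only" and "open" are said of these compounds alone.

In an in vitro ADME assay on microsomes from liver (Homo sapiens) for metabolic stability (on this read-out higher numbers stand for a longer-lived compound and lower numbers for a shorter-lived compound), compound 1 `C[C@@H](c1ccc(Cl)cc1)N1Cc2cncn2C(CC2(C)COC2)S1(=O)=O` gives 1.27 h. Compound 2 `CC(C)CC1n2cncc2CN([C@H](C)c2ccc(Cl)cc2)S1(=O)=O` gives 0.0833 h. Within the data shown here, compound 1 has the higher of the two numbers measured so far, and the gap between them lies well beyond the scatter. Compound 3 `COC(C)(C)CC1n2cncc2CN([C@@H](C)c2ccc(Cl)cc2)S1(=O)=O` carries 1-methoxy-1-methylethyl in place of 3-methyloxetan-3-yl on a saturated chain carbon bound to a saturated ring carbon. Among the measured compounds shown here, no measured pair shows this change directly, so the expectation is tentative. A downward move in this assay, beyond the scatter, is expected, estimated as a 3.2-fold lower number from compound 1 to compound 3 (0.50 log units; beyond the scatter). For compound 3 the estimated half-life is 0.4 h, within a range of 0.15 h to 1 h.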

Compound 3, half-life: 0.2 h
The estimate for compound 3 lay 2.0-fold (0.30 log units) above the measured number, within the range that was stated.
By their numbers in this assay, from the lowest: compound 2; then compound 3; then compound 1.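

In this assay, replacing 3-methyloxetan-3-yl with 1-methoxy-1-methylethyl gives a 6.4-fold lower number from compound 1 to compound 3 (0.80 log units; beyond the scatter) and so shows that the read-out at this place, on a saturated chain carbon bound to a saturated ring carbon, responds to this change. The swap leaves the counts of heavy atoms, hydrogen-bond donors and hydrogen-bond acceptors unchanged, while the four-membered ring is lost. Nothing measured here explains the drop. Going by these compounds, whether a cyclobutyl ring or an amine at this place would keep the longer half-life of compound 1 remains open.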